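A Second Chloro Group Added to Compound 2

This account rests on a few compounds, and the source may have more. Where it says the series, first, only, none or still open, it means among the compounds named here.

Measured in a functional assay on MKN-45 cells (Homo sapiens) for inhibition, read by MTT assay, with a stated time of 72 h; a lower number here means a stronger inhibitor, a higher number a weaker inhibitor:
Compound 1, `COc1ccc(-n2nc(C(=O)Nc3ccc(Oc4ccnc5cc(OCCCN6CCC(C)CC6)c(OC)cc45)c(F)c3)c(C)cc2=O)cc1`, gives 400 nM.
Compound 2, `COc1cc2c(Oc3ccc(NC(=O)c4nn(-c5ccc(Cl)cc5)c(=O)cc4C)cc3F)ccnc2cc1OCCCN1CCC(C)CC1`, gives 150 nM.

For the measured compounds named here, compound 2 holds the lower of the two numbers in this assay, and the only step measured so far is the one leading to it, a 2.7-fold lower number from compound 1 to compound 2 (0.43 log units; beyond the scatter), in which a chloro replaced a methoxy on an aromatic carbon.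

Compound 3, `COc1cc2c(Oc3ccc(NC(=O)c4nn(-c5ccc(Cl)cc5Cl)c(=O)cc4C)cc3F)ccnc2cc1OCCCN1CCC(C)CC1`, keeps the shared core of compound 2 and differs from it in one place: chloro in place of hydrogen on an aromatic carbon. Put another way, the 4-chlorophenyl of compound 2 becomes a 2,4-dichlorophenyl.

Going by the values given here, no measured pair shows what a second chloro on this ring does; the single step of a 2.7-fold lower number from compound 1 to compound 2 (0.43 log units; beyond the scatter) concerns an exchange at the position that already carries chloro in compound 2 and in compound 3, so it bears on the present change only loosely. With that limited basis, compound 3 is expected to stay close to compound 2 in this assay, with a step of a 1.3-fold lower number from compound 2 to compound 3 (0.10 log units; within the scatter) that need not exceed the scatter. Compound 3 is therefore estimated at 120 nM, with a range from 50 nM to 350 nM.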

Compound 3, half-maximal inhibitory concentration: 120 nM
For compound 3 middle estimate and measured number coincide at the digits printed; measured number inside the range.
By their numbers in this assay, from the lowest: compounds 3 and 2 (each within the scatter of the next); then compound 1.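

In this assay the step of a 1.3-fold lower number from compound 2 to compound 3 (0.10 log units; within the scatter) shows that a chloro is accepted on this aromatic carbon, ortho to a large group and meta to the chloro group already present, with the 4-chlorophenyl and the 2,4-dichlorophenyl not separable by their numbers. The wider exchange, 2,4-dichlorophenyl in place of 4-methoxyphenyl on an aromatic nitrogen, gives a 3.3-fold lower number from compound 1 to compound 3 (0.52 log units; beyond the scatter) and lies beyond the scatter, so the difference from compound 1 remains, while the second chloro adds nothing that can be read on top of what compound 2 already shows. Nothing available accounts for how this second chloro leaves the number within the scatter of compound 2.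

On these data alone, whether this place accepts other groups as it accepts chloro stays open, for instance a fluoro, a trifluoromethyl, an amine or a carboxylic acid in place of the added chloro. The compounds shown also leave open whether compound 2 and compound 3 would stay this close anywhere beyond this assay and whether the added chloro would matter on a different core.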